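This account rests on a few compounds, and the source may have more. Where it says the series, first, only, none or still open, it means among the compounds named here.

Compound 3 `O=C(NS(=O)(=O)c1ccc(F)cc1)c1ccc(Nc2nc(NC3(c4ccc(Cl)cc4)CC3)nc(OCC(F)(F)F)n2)cc1` gives 99% in an ADME assay on microsomes from liver (Rattus norvegicus) for metabolic stability, with a stated time of 10 min (on this read-out lower numbers stand for a less stable compound and higher numbers for a more stable compound), the highest of the three numbers recorded there. Its nearest neighbour is compound 1 `CC(C)(C)NC(=O)NCCS(=O)(=O)NC(=O)c1ccc(Nc2nc(NC3(c4ccc(Cl)cc4)CC3)nc(OCC(F)(F)F)n2)cc1`, which in this assay gives 93%; the step of a number 6 percentage points higher from compound 1 to compound 3 (within the scatter) lies within the scatter, so these two cannot be ranked against each other. Compound 2 `CCCCCNc1nc(Nc2ccc([N+](=O)[O-])cc2)nc(OCC(F)(F)F)n1` stands furthest away and in this assay gives 35%, a number beyond the scatter from compound 3.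

Compound 4 `CN(C)S(=O)(=O)NC(=O)c1ccc(Nc2nc(NC3(c4ccc(Cl)cc4)CC3)nc(OCC(F)(F)F)n2)cc1` has not yet been measured. It differs from compound 3 in a single place: dimethylamino in place of 4-fluorophenyl on a sulfonyl sulfur. Within the data shown here, only one measured step touches the same sulfonyl sulfur, namely a number 6 percentage points higher from compound 1 to compound 3 (within the scatter), and that exchange left the read-out within the scatter. Among the measured compounds shown here, no measured compound carries dimethylamino at that position, so the data give no direct precedent for this group. Given that the one comparable exchange produced no step beyond the scatter, no step beyond the scatter is expected here either, in either direction. Compound 4 is therefore estimated at 90% in this assay, with a range from 72% to 100%. The step implied by this estimate, a number 9 percentage points lower from compound 3 to compound 4 (within the scatter), is expected to remain within the scatter.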

Compound 4, percent of the compound remaining: 76%
Estimate against measurement, compound 4: 14 percentage points above; the range from low to high includes it.
By their numbers in this assay, from the lowest: compound 2; then compound 4; then compounds 1 and 3 (each within the scatter of the next).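

In this assay the group on this sulfonyl sulfur proves able to shift the read-out, which the earlier exchange between compound 1 and compound 3 did not show, as that step stayed within the scatter. Dimethylamino in place of 4-fluorophenyl gives a number 23 percentage points lower from compound 3 to compound 4 (beyond the scatter) and dimethylamino in place of 2-(((tert-butyl)carbamoyl)amino)ethyl gives a number 17 percentage points lower from compound 1 to compound 4 (beyond the scatter), so dimethylamino, the only one of the three groups joined to the sulfur through nitrogen and the one with the fewest heavy atoms, stands apart from two otherwise very different groups that cannot be ranked against each other. Nothing shown here accounts for this step.

The compounds shown leave open whether the nitrogen link or the small size of the group goes with the step: a methyl or an ethyl group on the same sulfur would separate the two, while a morpholine or a diethylamino group would keep the nitrogen link with more heavy atoms. They also leave open whether an unsubstituted phenyl would stay level with compound 3.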